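A few compounds are considered here, and "the series" means these few. Any claim that something is new, unique, unknown or untested is made for them only; others in the source may bear on it.

Measured in a functional assay on MCF7 cells (Homo sapiens) for inhibition, read by fluorescence, with a stated time of 72 h; a higher number here means a weaker inhibitor, a lower number a stronger inhibitor:
- Compound 1 `CC(C)n1cnc2c(NC(=N)N)nc(NCCO)nc21`: 12400 nM
- Compound 2 `CC(C)n1cnc2c(NC(=N)N)nc(NCCCO)nc21`: 8800 nM
- Compound 3 `CC[C@@H](N)COc1nc(NC(=N)N)c2ncn(C(C)C)c2n1`: > 100000 nM, which is a limit and not a number

Among these three, compound 3 is the weakest. Going from the shorter hydroxy chain to the longer one gives a 1.4-fold lower number from compound 1 to compound 2 (0.15 log units; within the scatter). Swapping either amino chain for 2-aminobutoxy gives an at least 8.0-fold higher number from compound 1 to compound 3 (0.90 log units; beyond the scatter) and an at least 11-fold higher number from compound 2 to compound 3 (1.05 log units; beyond the scatter).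

Compound 4 `CC[C@H](N)COc1nc(NC(=N)N)c2ncn(C(C)C)c2n1` has the same atoms and bonds as compound 3 and keeps the 2-aminobutoxy group. Within the data shown here, the only change is in how one centre is drawn: the two compounds have the same atoms and bonds; at least one stereo element is drawn with a configuration in one of them and without one in the other: 1 of 2 stereo elements differ; a stereocentre at a saturated chain carbon is drawn R in compound 3 and S in compound 4. Among the measured compounds shown here, no measured step alters a stereocentre, so none shows how large this change might be. The two steps to compound 3 bear on it only indirectly, since compound 4 retains the group that those steps introduced. In this assay, compound 4 is therefore expected to stay weak, in the same region as compound 3, with no clear step beyond the scatter. It may well also read only as a limit.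

The expected change is an at least 1.2-fold lower number from compound 3 to compound 4 (0.09 log units; that floor lies within the scatter).

For compound 4 the estimated value is 80000 nM, with an expected range of 20000 nM to 150000 nM.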

Compound 4, half-maximal inhibitory concentration: 16300 nM
The estimate for compound 4 lay 4.9-fold (0.69 log units) above the measured number; the whole stated range lies above it.
By their numbers in this assay, from the lowest: compounds 2, 1 and 4 (each within the scatter of the next). At a limit, above all of these: compound 3.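

In this assay, the way one stereocentre is drawn can alone move the number, with the atoms and bonds unchanged: the saturated chain carbon drawn S rather than R gives an at least 6.1-fold lower number from compound 3 to compound 4 (0.78 log units; beyond the scatter), a change in how one centre is drawn and not in any group. The steps from the amino chains to 2-aminobutoxy had looked costly, yet with the S drawing they give a 1.9-fold higher number from compound 2 to compound 4 (0.27 log units; within the scatter) and a 1.3-fold higher number from compound 1 to compound 4 (0.12 log units; within the scatter), both within the scatter, so the 2-aminobutoxy group does not by itself bring the loss seen with compound 3. That first step is only a floor and its true size stays unknown, because compound 3 reads as a limit and not a number: the limit of > 100000 nM in this assay, at which 1 of the 4 values shown sits.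

The compounds shown leave open how far apart the two drawings really lie, and whether a similar gap appears with other chains. They also leave open whether the chain amine matters, as a 2-hydroxybutoxy group or a carboxylic acid in its place would show, and whether a longer chain would behave the same way.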